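Cyclohexyl for sec-butyl on an enaminone amine

This account rests on a few compounds, and the source may have more. Where it says the series, first, only, none or still open, it means among the compounds named here.

Compound 1 `CCC(C)NC(=C\C(=O)/C=C/c1ccc(O)c(OC)c1)/C=C/c1ccc(O)c(OC)c1` and compound 2 `COc1cc(/C=C/C(=O)/C=C(/C=C/c2ccc(O)c(OC)c2)NC2CCCCC2)ccc1O` share one core, while compound 3 `CCC(C)NC(=C\C(=O)/C=C/c1ccc(O)cc1)/C=C/c1ccc(O)cc1` and compound 4 `O=C(/C=C(/C=C/c1ccc(O)cc1)NC1CCCCC1)/C=C/c1ccc(O)cc1` share another; the difference between the two cores is not broken down here. In a functional assay on HT-29 cells (Homo sapiens) for inhibition, read by sulforhodamine B assay, with a stated time of 72 h (on this read-out higher numbers stand for weaker inhibition and lower numbers for stronger inhibition), compound 1 gives 22300 nM. Compound 2 reaches only the limit of this assay, > 25000 nM. Compound 3 gives 15600 nM in this assay. The change cyclohexyl in place of sec-butyl on an amine nitrogen gave an at least 1.1-fold higher number from compound 1 to compound 2 (0.04 log units; that floor lies within the scatter), a floor that rests on (the limit of > 25000 nM in this assay, at which 1 of the 3 values shown sits). The same change, (cyclohexyl in place of sec-butyl on an amine nitrogen), carries compound 3 into compound 4. Because the measured step of an at least 1.1-fold higher number from compound 1 to compound 2 (0.04 log units; that floor lies within the scatter) points toward a higher number, compound 4 is expected to show a step of a 1.3-fold higher number from compound 3 to compound 4 (0.13 log units; within the scatter). For compound 4 the estimate in this assay is 21000 nM, between 10000 nM and 45000 nM.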

Compound 4, half-maximal inhibitory concentration: 5900 nM
Beside the measured number, compound 4's estimate is 3.6-fold (0.55 log units) above it, and the stated range ends above it.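

In this assay, cyclohexyl in place of sec-butyl on an amine nitrogen gives a 2.6-fold lower number from compound 3 to compound 4 (0.42 log units; beyond the scatter), and this differs from the step seen on the core of compound 1: the same change on two cores in this assay, an at least 1.1-fold higher number (0.04 log units; that floor lies within the scatter) from compound 1 to compound 2 and a 2.6-fold lower number (0.42 log units; beyond the scatter) from compound 3 to compound 4, at least 2.9-fold (0.47 log units) apart, beyond the scatter of two such steps In this series, then, the step measured on one core did not carry over to the other, although two pairs cannot show how the change behaves on any further core. Compound 2 stands at a limit of the assay, so the step on its core is only a floor and its true size stays unknown: the limit of > 25000 nM in this assay, at which 1 of the 4 values shown sits.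

The compounds shown leave open how a benzylamino or cyclopentylamino group would behave on each of the two cores. They also leave open which feature of the cores sets the two steps apart.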